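Methylsulfonyl on the propyl chain: working notes

The source may report more compounds than this note shows. Statements on the series, on what has been measured and on what is new or still open speak of the compounds shown alone.

In a physicochemical assay for lipophilicity, read by HPLC, in phosphate buffer, measured as octanol-water partition, at pH 7.4, tested at 100 uM (a higher number here means a more lipophilic compound, a lower number a more polar compound), compound 1 (`CCOc1cc(C)c(-c2cccc(COc3ccc(NCC(=O)O)c(F)c3)c2)c(C)c1`) is recorded as "not determined" (no result reported) and compound 2 (`CCOc1cc(C)c(-c2cccc(CNc3ccc(OCC(=O)O)cc3)c2)c(C)c1`) as "not determined" (no result reported) with no result reported for either. Among the compounds with values here, compound 3 (`CCCOc1cc(C)c(-c2cccc(CNc3ccc(OCC(=O)O)c(F)c3)c2)c(C)c1`) gives 3.59 as the only number, so it cannot yet be ranked against anything. Compound 4 (`Cc1cc(OCCCS(C)(=O)=O)cc(C)c1-c1cccc(CNc2ccc(OCC(=O)O)c(F)c2)c1`) differs from compound 3 by one change (methylsulfonyl in place of hydrogen on a saturated chain carbon, three bonds along the chain from an oxygen on an aromatic ring): propyl becomes 3-(methylsulfonyl)propyl. Within the data shown here, no measured step is available to calibrate this change, so the expectation rests on the structural change alone. A clear fall in this assay beyond the scatter is expected, and the estimated move is a number 1.49 log units lower from compound 3 to compound 4 (beyond the scatter) in size. For compound 4 the estimated value is 2.1 with an expected range (1.6 to 2.6).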

Compound 4, distribution coefficient: 1.73
The estimate for compound 4 lay 0.37 log units above the measured number; the measured number falls inside the stated range.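

In this assay, within the data shown here, methylsulfonyl on the saturated chain carbon, three bonds along the chain from an oxygen on an aromatic ring, gives the first readable step, a number 1.86 log units lower from compound 3 to compound 4 (beyond the scatter), so this chain position responds strongly to this change in this read-out. Among these compounds, no step involving compound 1 or compound 2 can be read. No supporting data bear on the origin of this step.

Going by these compounds, whether an amine or a carboxylic acid at the same chain end would give a step of similar size remains open. So does the effect of moving methylsulfonyl onto a longer chain.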